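Methyl for hydrogen on the benzylic carbon: cytotoxicity series

The source may hold more compounds than are shown below. What is called first, only, known or untested is meant among the compounds shown, and "the series" means these compounds.

Measured compounds:
Compound 1 `COc1ccc(C(=O)CSc2nc(Cc3cccc(Br)c3)c(C)c(=O)[nH]2)cc1`; in an ADME assay on MT4 cells (Homo sapiens) for cytotoxicity (a higher number here means that more compound is tolerated, a lower number that less compound is tolerated), compound 1 gives >= 196000 nM, which is a limit of the assay.
Compound 2 `COc1ccc(C(=O)CSc2nc(C(c3ccccc3)c3ccccc3)c(C)c(=O)[nH]2)cc1`; in this assay compound 2 gives > 274000 nM, also a limit of the assay.
Compound 3 `CCc1c(Cc2cccc(Br)c2)nc(SCC(=O)c2ccc(OC)cc2)[nH]c1=O`; in this assay compound 3 gives 142000 nM.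

From compound 1 to compound 3 the change is methyl in place of hydrogen on a saturated chain carbon bound to an aromatic carbon, and it produced an at least 1.3-fold lower number from compound 1 to compound 3 (0.13 log units; that floor lies within the scatter). How the cores of compound 1 and compound 2 differ is not broken down here. Compound 4 `CCc1c(C(c2ccccc2)c2ccccc2)nc(SCC(=O)c2ccc(OC)cc2)[nH]c1=O` is not yet measured; it carries the same change from compound 2, (methyl in place of hydrogen on a saturated chain carbon bound to an aromatic carbon), at a place worded identically, so the change is the same. The step from compound 2 to compound 4 is expected to be small, an at least 1.1-fold lower number from compound 2 to compound 4 (0.07 log units; that floor lies within the scatter), resting on an at least 1.3-fold lower number from compound 1 to compound 3 (0.13 log units; that floor lies within the scatter). Since the value of compound 2 is a limit, compound 4 may again return only a limit. Compound 4 is estimated at 230000 nM, between 110000 nM and 400000 nM.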

Compound 4, half-maximal cytotoxic concentration: > 266000 nM
Compound 4: no number, only a limit; the forecaster's own chance of this, stated with the estimate: 50%; middle value at least 1.1-fold (0.06 log units) from the limit.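

In this assay compound 4 gives > 266000 nM, a limit of the assay. Among the compounds shown here, compound 2 also gave only a limit, so no step between compound 2 and compound 4 can be read. Going by these compounds, whether methyl in place of hydrogen changes the number on the core of compound 2 stays open.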